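The source may hold more compounds than are shown below. What is called first, only, known or untested is meant among the compounds shown, and "the series" means these compounds.

In a physicochemical assay for solubility (on this read-out higher numbers stand for higher solubility and lower numbers for lower solubility), compound 1 `CNC(=O)c1cc(C(=O)NC2CCC2)cn(Cc2ccccn2)c1=O` reads >= 103 ug/mL, which is a limit of the assay and not an exact number. Compound 2 `CNC(=O)c1cc(C(=O)NC2CC2)cn(Cc2cccc3cn[nH]c23)c1=O` reads >= 181 ug/mL, also a limit. Compound 3 `CNC(=O)c1cc(C(=O)NC2CCC2)cn(Cc2ccccc2)c1=O` keeps the core of compound 1 and makes a single change, phenyl in place of pyridin-2-yl on a saturated chain carbon bound to an aromatic nitrogen. For the measured compounds named here, no measured pair of compounds shows this change, and the expectation is therefore uncertain: a moderate fall in this assay, with a wide margin. The expected step is an at least 1.5-fold lower number from compound 1 to compound 3 (0.19 log units; that floor lies within the scatter). For compound 3 the estimate is 65 ug/mL, with an expected range of 15 ug/mL to 200 ug/mL.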

Compound 3, solubility: 28 ug/mL
Compound 3: middle estimate off by 2.3-fold (0.37 log units), on the high side; the measured number falls inside the stated range.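

Replacing pyridin-2-yl with phenyl on a saturated chain carbon bound to an aromatic nitrogen gives the first step read at this position in this assay, and it is beyond the usual scatter: an at least 3.6-fold lower number from compound 1 to compound 3 (0.56 log units; beyond the scatter). The change removes the hydrogen-bond acceptor of the pyridin-2-yl, and the number falls with it. The size of the step is only a floor, as compound 1 reads a limit: the limit of >= 103 ug/mL in this assay, at which 1 of the 3 values shown sits.

On these data alone, whether an amine or a carboxylic acid on the phenyl would raise the number stays open. So does whether this change gives a similar step on another core.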